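Aryloxy change in a fused bicyclic amine series

The compounds below may be only part of what the source reports. "The series", "measured", "known", "first", "only" and "open" are said of these compounds alone.

Compound 1: `c1ccc(OCC2[C@H]3CN(Cc4cn5ccccc5n4)C[C@@H]23)cc1`
Compound 2: `Cn1c(CN2C[C@@H]3C(COc4cc(F)ccc4F)[C@@H]3C2)nc2ccccc21`
Compound 3 (not yet measured): `Cn1c(CN2C[C@@H]3C(COc4ccc(Cl)cc4F)[C@@H]3C2)nc2ccccc21`

In an in vitro assay on HEK293 cells with metabotropic glutamate receptor 2 (Rattus norvegicus) as the target, read by FLIPR, in the presence of a further agent that is not named here (a lower number here means that less compound is needed, a higher number that more compound is needed for the effect), compound 1 reaches only a limit, > 10000 nM. Among the compounds with values here, compound 2 gives 7 nM in this assay and so holds the only number of the two. Compound 1 sits at the limit of > 10000 nM in this assay, at which 1 of the 2 values shown sits. Compound 3 differs from compound 2 by 4-chloro-2-fluorophenyl in place of 2,5-difluorophenyl on an oxygen on a saturated carbon. Within the data shown here, no step between measured compounds exists, so this change has no measured guide. The step of a 1.2-fold lower number from compound 2 to compound 3 (0.07 log units; within the scatter) is expected to stay within the usual scatter, in no clear direction. Compound 3 is estimated at 6 nM, from 2 nM to 25 nM.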

Compound 3, half-maximal effective concentration: 8 nM
The estimate for compound 3 lay 1.3-fold (0.12 log units) below the measured number; low and high end bracket the measured number.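

In this assay, the series now has its first readable step, a 1.1-fold higher number from compound 2 to compound 3 (0.06 log units; within the scatter), for 4-chloro-2-fluorophenyl in place of 2,5-difluorophenyl on an oxygen on a saturated carbon. This place therefore accepts both halogen-bearing phenyl groups, with values within the scatter of each other. No measured property among the data shown bears on this step.

Going by these compounds, whether this place also accepts a carboxylic acid or an amine on the phenyl ring remains open. On these data alone, compound 1 differs from compound 2 in more than one place, so which difference matters also remains open.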